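This account rests on a few compounds, and the source may have more. Where it says the series, first, only, none or still open, it means among the compounds named here.

Compound 2 `O=C(Nc1ccc(Oc2ccnc3[nH]ccc23)c(F)c1)c1cc(-c2ccc(F)cc2)ncn1` was tested in a functional assay on PC-3 cells (Homo sapiens) for cytotoxicity, read by MTT assay, with a stated time of 72 h (a higher number here means a weaker inhibitor, a lower number a stronger inhibitor), and the result for compound 2 is recorded only as "not active" (no number reported), so no single number places it on the scale. Compound 1 `Cc1ccc(-c2cc(C(=O)Nc3ccc(Oc4ccnc5[nH]ccc45)cc3)ncn2)cc1`, which carries a methyl group where compound 2 carries a fluoro, is the one reference point with a number: in this assay compound 1 gives 9880 nM. Compound 3 `Cc1ccc(-c2cc(C(=O)Nc3ccc(Oc4ccnc5[nH]ccc45)c(F)c3)ncn2)cc1` takes the route from compound 2 by methyl in place of fluoro on an aromatic carbon. Within the data shown here, with no measured step between any pair of compounds that differ in one place, the size of the step in this assay from compound 2 to compound 3 cannot be read from the data; the one number available points to weak inhibition of this kind. Because compound 1 gives 9880 nM, compound 3 is expected to land near that level, at an estimated 15000 nM, within 5000 nM to 50000 nM.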

Compound 3, half-maximal inhibitory concentration: 24900 nM
The estimate for compound 3 lay 1.7-fold (0.22 log units) below the measured number; the measured number falls inside the stated range.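

Among these compounds, this is the first measured step: in this assay, fluoro in place of hydrogen on an aromatic carbon of the core gives a 2.5-fold higher number from compound 1 to compound 3 (0.40 log units; beyond the scatter), so the change moves the number upward, towards weaker inhibition, by a modest amount beyond the scatter. Among the compounds shown here, with this fluoro present and the 4-methylphenyl group in place, compound 3 still gives a number, 24900 nM, while compound 2, with 4-fluorophenyl, is recorded only as not active, and no step to or from compound 2 can be read. No evidence is available that bears on the reason for either result.

The compounds shown leave open how an amine or a methoxy group in place of the methyl of the 4-methylphenyl group would read in this assay. They also leave open whether the fluoro step would keep its direction and size on a different aryl group.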